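Moving a Methoxy Group on a Weak Thiosemicarbazone

A few compounds are considered here, and "the series" means these few. Any claim that something is new, unique, unknown or untested is made for them only; others in the source may bear on it.

Compound 1 `COc1ccccc1NC(=S)N/N=C/c1ccc2ccccc2n1`: > 100000 nM
Compound 2 `CN(C)C(=S)N/N=C/c1cc2cccnc2s1`: 48400 nM
Compound 3 `CN(C)C(=S)N/N=C/c1ccc2ccccc2n1`: 90 nM

In a functional assay on HeLa cells (Homo sapiens) for antiproliferative activity, read by sulforhodamine B assay, with a stated time of 72 h (a higher number here means a weaker inhibitor, a lower number a stronger inhibitor), compound 1 gives > 100000 nM, which is a limit of the assay and not a number. The two other measured compounds return numbers: compound 2 gives 48400 nM and compound 3 gives 90 nM. Going by the values given here, no two of these three differ in only one place, so no measured step can be carried over directly.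

Compound 4 `COc1cccc(NC(=S)N/N=C/c2ccc3ccccc3n2)c1` keeps the core of compound 1 and changes a single group, with 3-methoxyphenyl in place of 2-methoxyphenyl on an amide-type nitrogen. The two groups have the same atoms, joined differently, so only a modest change is expected in this assay. Any number for compound 4 would have to lie on the stronger side of the limit held by compound 1, and a further limit remains quite possible. Compound 4 is therefore expected to stay far weaker than compound 3 at 90 nM. The expected move is an at least 2.5-fold lower number from compound 1 to compound 4 (0.39 log units; beyond the scatter). For compound 4 the estimated value is 40000 nM, with an expected range of 8000 nM to 100000 nM.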

Compound 4, half-maximal inhibitory concentration: 74500 nM
For compound 4 the middle estimate is 1.9-fold (0.27 log units) below the measured one, within the range that was stated.
By their numbers in this assay, from the lowest: compound 3; then compounds 2 and 4 (each within the scatter of the next). At a limit, above all of these: compound 1.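

In this assay compound 4 gives 74500 nM, so 3-methoxyphenyl on the amide-type nitrogen whose other neighbour is the thiocarbonyl carbon returns a measurable number, which 2-methoxyphenyl at the same place did not. Compound 1 gives > 100000 nM, which is a limit of the assay and not a number. The change of group therefore reads only as an at least 1.3-fold lower number from compound 1 to compound 4 (0.12 log units; that floor lies within the scatter), and this floor does not establish a real gain, because the true value of compound 1 remains hidden: the limit of > 100000 nM in this assay, at which 1 of the 4 values shown sits.

The compounds shown leave open how other groups on this nitrogen would behave, for example a plain phenyl without the methoxy group, a chlorophenyl, a hydroxyphenyl or a short alkyl chain such as ethyl. They also leave open whether the number seen for compound 4 marks a real difference between the two methoxyphenyl groups, which would require a value for compound 1 that is more than a limit, and whether the same difference would appear in cell lines other than HeLa.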